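Swapping 4-hydroxy-3-methoxyphenyl for 3,4,5-trihydroxyphenyl

The compounds below may be only part of what the source reports. "The series", "measured", "known", "first", "only" and "open" are said of these compounds alone.

In a physicochemical assay, read by spectrophotometry, with a stated time of 30 min (on this read-out lower numbers stand for stronger inhibition and higher numbers for weaker inhibition), compound 1 (`O=C(CCc1nc2ccccc2c(=O)[nH]1)N/N=C/c1ccc([N+](=O)[O-])cc1`) gives 328000000 nM and compound 2 (`O=C(CCc1nc2ccccc2c(=O)[nH]1)N/N=C/c1ccccc1`) gives 734000000 nM while compound 3 (`COc1cc(/C=N/NC(=O)CCc2nc3ccccc3c(=O)[nH]2)ccc1O`) gives 204000000 nM on the same scale. Two steps fix where the last of these stands: a 1.6-fold lower number from compound 1 to compound 3 (0.21 log units; within the scatter) and a 3.6-fold lower number from compound 2 to compound 3 (0.56 log units; beyond the scatter) on this read-out. Compound 4 (`O=C(CCc1nc2ccccc2c(=O)[nH]1)N/N=C/c1cc(O)c(O)c(O)c1`) has 3,4,5-trihydroxyphenyl in place of 4-hydroxy-3-methoxyphenyl on a carbon with a double bond to nitrogen. The nearest guide is the modest 3.6-fold lower number from compound 2 to compound 3 (0.56 log units; beyond the scatter) when that same group replaced phenyl, and a 2.2-fold higher number from compound 1 to compound 2 (0.35 log units; beyond the scatter) is similarly modest. A modest step to a lower number is therefore expected in this assay for compound 4 (a 2.3-fold lower number from compound 3 to compound 4 (0.36 log units; beyond the scatter)). Compound 4 is estimated at 90000000 nM with an expected range from 30000000 nM to 220000000 nM on this read-out.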

Compound 4, half-maximal inhibitory concentration: 81000000 nM
For compound 4 the middle estimate is 1.1-fold (0.05 log units) above the measured one; the measured number falls inside the stated range.
By their numbers in this assay, from the lowest: compound 4; then compounds 3 and 1 (each within the scatter of the next); then compound 2.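

In this assay, 3,4,5-trihydroxyphenyl on this carbon goes further than 4-hydroxy-3-methoxyphenyl did, with a 2.5-fold lower number from compound 3 to compound 4 (0.40 log units; beyond the scatter), so the number at this position had not yet bottomed out. The new group also widens the gap to phenyl, with a 9.1-fold lower number from compound 2 to compound 4 (0.96 log units; beyond the scatter), and gives the first clear drop below 4-nitrophenyl, with a 4.0-fold lower number from compound 1 to compound 4 (0.61 log units; beyond the scatter). Nothing supplied explains this gain.

From the compounds shown here alone, it stays open whether all three hydroxy groups are needed. Going by these compounds, how an amine or a carboxylic acid on this ring would read also remains unknown.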